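The compounds below may be only part of what the source reports. "The series", "measured", "known", "first", "only" and "open" are said of these compounds alone.

Compound 1 `O=C(Nc1ccc([N+](=O)[O-])cc1)c1cc(Cl)ccc1O`: 2280 nM
Compound 2 `O=C(Nc1ccc(F)c(Cl)c1)c1cc(Cl)ccc1O`: 2440 nM
Compound 3 `O=C(Nc1ccc(F)cc1)c1cc(Cl)ccc1O`: not yet measured

Both measured compounds were tested in a toxicity assay on Vero C1008 cells (Chlorocebus sabaeus) for cytotoxicity, read by MTT assay, with a stated time of 48 h; on this read-out higher numbers stand for lower toxicity in this test and lower numbers for higher toxicity in this test. Compound 2, at 2440 nM, lies within the usual scatter of compound 1, at 2280 nM, so the two numbers cannot be ranked. Compound 3 differs from compound 2 in one place: hydrogen in place of chloro on an aromatic carbon. This puts hydrogen in place of chloro on an aromatic carbon, and the fluoro group stays. Within the data shown here, no measured pair here differs in only one place, so the data offer no direct guide to this change. Only a small move toward a higher number, and so toward lower toxicity in this assay, is expected, probably not beyond the scatter. The expected step is a 1.4-fold higher number from compound 2 to compound 3 (0.13 log units; within the scatter). Compound 3 is estimated at 3300 nM, with an expected range of 1300 nM to 8000 nM.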

Compound 3, half-maximal cytotoxic concentration: 6780 nM
Compound 3: the middle estimate sits 2.1-fold (0.31 log units) below what was measured, within the range that was stated.
By their numbers in this assay, from the lowest: compounds 1 and 2 (each within the scatter of the next); then compound 3.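

In this assay, hydrogen in place of chloro on an aromatic carbon, ortho to the fluoro group, gives a 2.8-fold higher number from compound 2 to compound 3 (0.44 log units; beyond the scatter), showing that this position registers in the read-out and that losing the chloro group moves the number toward lower toxicity in this test. The other single change, fluoro in place of nitro on an aromatic carbon, gives a 3.0-fold higher number from compound 1 to compound 3 (0.47 log units; beyond the scatter), so compound 3 stands apart from both compound 1 and compound 2, although those two could not be ranked against each other. Nothing measured here accounts for either step.

At this position only chloro and hydrogen are shown, so the effect of a methyl or methoxy group there remains open. As far as these compounds go, whether an amine or a carboxylic acid in place of the fluoro group would raise or lower the number is also open.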